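Removing a Methyl from the Sulfonyl Phenyl

A few compounds are considered here, and "the series" means these few. Any claim that something is new, unique, unknown or untested is made for them only; others in the source may bear on it.

Compound 1 `O=C(O)c1ccc(NC(=O)[C@@H]2CC(O)CN2S(=O)(=O)c2ccccc2)cc1` gives 27.3% in a functional assay on the whole organism for inhibition, with Rattus norvegicus as the target, read by paw edema, with stated times of 1 h and 2 h, at a dose of 100 mg/kg by the oral route; a lower number here means less inhibition, a higher number more inhibition at the dose given (going by the name of the read-out).
Compound 2 `Cc1ccccc1S(=O)(=O)N1CCC[C@H]1C(=O)Nc1ccc(C(=O)O)cc1` gives 36.3% in this assay.

Compound 2 and compound 1 give numbers that lie within the usual scatter of each other, so neither stands apart. Compound 3 `O=C(O)c1ccc(NC(=O)[C@@H]2CCCN2S(=O)(=O)c2ccccc2)cc1` differs from compound 2 by hydrogen in place of methyl on an aromatic carbon. Among the compounds with values here, no measured pair shows this change alone, so its size in this assay is uncertain; a step of no more than the scatter, in either direction, is expected, with a number 6.3 percentage points lower from compound 2 to compound 3 (within the scatter) as the expected step from compound 2 to compound 3. For compound 3 the estimate in this assay is 30%, in the range 15% to 45%.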

Compound 3, a percentage reported as inhibition, in the whole organism at one dose (the size of the read-out at that dose, not a potency): 29.4%
Compound 3: middle estimate off by 0.6 percentage points, on the high side; measured number inside the range.
By their numbers in this assay, from the lowest: compounds 1, 3 and 2 (each within the scatter of the next).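

In this assay the change from 2-methylphenyl to phenyl gives a number 6.9 percentage points lower from compound 2 to compound 3 (within the scatter) and so does not separate the two compounds at this aromatic carbon. Hydrogen in place of hydroxy on a saturated ring carbon likewise gives a number 2.1 percentage points higher from compound 1 to compound 3 (within the scatter) and adds a second change that stays within the scatter. No available measurement explains either step. From the compounds shown here alone, whether an amine or an ethyl group on that aromatic carbon would move the number beyond the scatter remains open.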